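Swapping a pyrazole for fluorophenyl on a second core

A few compounds are considered here, and "the series" means these few. Any claim that something is new, unique, unknown or untested is made for them only; others in the source may bear on it.

Of the compounds shown here, three have been tested so far in a functional assay on SNU-5 cells (Homo sapiens) for inhibition, read by CCK-8 assay, with a stated time of 72 h; on this read-out higher numbers stand for weaker inhibition and lower numbers for stronger inhibition. Compound 2 `CC(c1ccc2ncc(-c3cnn(C)c3)cc2c1)n1nnc2ncc(-c3ccncc3)nc21` gives 1.2 nM in this assay. Compound 1 `CC(c1ccc2ncc(-c3ccc(F)cc3)cc2c1)n1nnc2ncc(-c3ccncc3)nc21` differs from it by 4-fluorophenyl in place of 1-methyl-1H-pyrazol-4-yl on an aromatic carbon, and compound 1 gives 7 nM. For the measured compounds named here, that step, a 5.8-fold higher number from compound 2 to compound 1 (0.77 log units; beyond the scatter), is the only measured example of this change. Compound 3 `CC(c1c(F)cc2ncc(-c3cnn(C)c3)cc2c1F)n1nnc2ncc(-c3ccncc3)nc21` sits on a different core from compound 2; the difference between the two cores is not broken down here. Compound 3 gives 1.2 nM, so compound 2 and compound 3 are level at the digits printed and together hold the lowest numbers of the three.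

Compound 4 `CC(c1c(F)cc2ncc(-c3ccc(F)cc3)cc2c1F)n1nnc2ncc(-c3ccncc3)nc21` has not yet been measured. It differs from compound 3 by 4-fluorophenyl in place of 1-methyl-1H-pyrazol-4-yl on an aromatic carbon, and the place of the change reads the same word for word as in the step from compound 2 to compound 1, so this is the same change made on the core of compound 3. Going by the values given here, the only guide is the step from compound 2 to compound 1, a 5.8-fold higher number from compound 2 to compound 1 (0.77 log units; beyond the scatter), taken once on a different core. The expected step is a 5.8-fold higher number from compound 3 to compound 4 (0.77 log units; beyond the scatter), resting on that single earlier step and on the value of compound 3, 1.2 nM. Compound 4 is therefore expected to give about 7 nM in this assay, with a likely range from 3 nM to 17 nM.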

Compound 4, half-maximal inhibitory concentration: 7.2 nM
For compound 4 the middle estimate is 1.0-fold (0.01 log units) below the measured one; measured number inside the range.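

In this assay, replacing 1-methyl-1H-pyrazol-4-yl with 4-fluorophenyl on the core of compound 3 gives a 6.0-fold higher number from compound 3 to compound 4 (0.78 log units; beyond the scatter), so inhibition weakens on this core as well. Set beside the earlier example, the change has much the same size on both cores: the same change on two cores in this assay, a 5.8-fold higher number (0.77 log units; beyond the scatter) from compound 2 to compound 1 and a 6.0-fold higher number (0.78 log units; beyond the scatter) from compound 3 to compound 4, 1.0-fold (0.01 log units) apart, within the scatter of two such steps

This shows that, for these two cores, the size of the step measured on one core would have served as a fair guide to the step on the other, but two cores are a very small sample, so it does not establish a rule for the whole series, and it does not show why the 4-fluorophenyl compounds give the higher numbers or what separates the two cores themselves.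

For the compounds shown here, all four compounds carry one of only two groups at this place, so it remains open how a small amine, a carboxylic acid or a longer chain of carbon atoms there would behave. From the compounds shown here alone, it also remains open whether the step would keep its size on a third core, or whether any such group could give a lower number than the 1-methyl-1H-pyrazol-4-yl compounds do.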